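Compound 3: a difluorophenyl variant of compound 2

The source may report more compounds than this note shows. Statements on the series, on what has been measured and on what is new or still open speak of the compounds shown alone.

Measured so far:
compound 1 `CC(C)(C)Cc1c(-c2ccoc2)sc(N)c1C(=O)c1ccc(Cl)cc1`: 1%
compound 2 `CC(C)(C)Cc1c(-c2ccc(F)cc2)sc(N)c1C(=O)c1ccc(Cl)cc1`: 9%

In an assay on CHO cells for displacement of a labelled ligand from adenosine receptor A3 (Homo sapiens), read by scintillation counting, tested at 10 uM (a higher number here means more inhibition at the concentration tested (going by the name of the read-out), a lower number less inhibition), compound 1 gives 1%; compound 2 gives 9%. Among the measured compounds shown here, compound 2 carries the larger of the two numbers, but the only measured step, a number 8 percentage points higher from compound 1 to compound 2 (within the scatter), is within the scatter, so neither compound stands apart from the other; both sit at the low end of the read-out.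

Compound 3 `CC(C)(C)Cc1c(-c2cc(F)ccc2F)sc(N)c1C(=O)c1ccc(Cl)cc1` is not yet measured. It differs from compound 2 in one place: 2,5-difluorophenyl in place of 4-fluorophenyl on an aromatic carbon.

For the measured compounds named here, no measured step concerns this particular exchange. Going by the values given here, the one step known, from compound 1 to compound 2, swapped a different group at the same place and stayed within the scatter. There is therefore no basis for expecting a step beyond the scatter in this assay, and the expected step from compound 2 to compound 3 is a number 1 percentage points lower from compound 2 to compound 3 (within the scatter). For compound 3 the estimate in this assay is 8%, with a range from -5% to 25%.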

Compound 3, a percentage reported as inhibition, at one concentration (the size of the read-out at that concentration, not a potency): 1%
The estimate for compound 3 lay 7 percentage points above the measured number, within the range that was stated.
By their numbers in this assay, from the lowest: compounds 1, 3 and 2 (each within the scatter of the next).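

In this assay exchanging 4-fluorophenyl for 2,5-difluorophenyl gives a number 8 percentage points lower from compound 2 to compound 3 (within the scatter) and exchanging furan-3-yl for 2,5-difluorophenyl gives no change at the digits printed from compound 1 to compound 3 (within the scatter) on this aromatic carbon next to the ring sulfur. The three groups tested at this position now all lie within the scatter of one another, so neither the second fluorine nor either exchange of the aromatic ring gives a step that can be read here. No evidence bears on the cause of this result.

Going by these compounds, whether a non-aromatic group at this carbon, such as an aminomethyl group or a carboxylic acid, would move the number beyond the scatter stays open. On these data alone, the contribution of the neopentyl, amino and (4-chlorophenyl)carbonyl groups also stays open, as all three compounds carry them unchanged.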